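A few compounds are considered here, and "the series" means these few. Any claim that something is new, unique, unknown or untested is made for them only; others in the source may bear on it.

Working notes on the series, read in a functional assay on the whole organism with Mus musculus as the target, in the rotarod test; a lower number here means that less compound is needed, a higher number that more compound is needed for the effect. Compound 3 `CN(C(=O)CNC(=O)c1ccccc1)c1ccc(Cl)cc1C(=O)c1ccccc1Cl` gives > 100 mg/kg and this is a limit of the assay, not a number. That leaves compound 3 at the limit of > 100 mg/kg in this assay, at which 1 of the 3 values shown sits. Compound 1 `CCCCCC(=O)NCC(=O)N(C)c1ccc(Cl)cc1C(=O)c1ccccc1Cl` gives 90 mg/kg on the shared core. Compound 2 `CC(=O)NCC(=O)N(C)c1ccc(Cl)cc1C(=O)c1ccccc1Cl` gives 58 mg/kg on the same core. The step between these two is a 1.6-fold lower number from compound 1 to compound 2 (0.19 log units; within the scatter).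

Compound 4 `CCCCCCC(=O)NCC(=O)N(C)c1ccc(Cl)cc1C(=O)c1ccccc1Cl` differs from compound 3 as follows: hexyl in place of phenyl on a carbonyl carbon. In words, this is hexyl in place of phenyl on a carbonyl carbon, the amide-type nitrogen remaining its other neighbour. The measured steps that bear on it are the two that arrive at phenyl, namely an at least 1.1-fold higher number from compound 1 to compound 3 (0.04 log units; that floor lies within the scatter) and an at least 1.7-fold higher number from compound 2 to compound 3 (0.23 log units; that floor lies within the scatter). Both are floors only, so neither fixes a size or a firm direction for leaving phenyl. Compound 1 is the nearest comparison, with pentyl at that place and a value of 90 mg/kg to anchor the expectation. No step beyond the scatter is therefore expected in this assay. The step is estimated as an at least 1.0-fold lower number from compound 3 to compound 4 (0.02 log units; that floor lies within the scatter) and remains uncertain on the side of the limit. For compound 4 the expected value is 95 mg/kg, with an estimated range from 50 mg/kg to 170 mg/kg.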

Compound 4, dose for half-maximal effect: 70 mg/kg
The estimate for compound 4 lay 1.4-fold (0.13 log units) above the measured number, and the stated range covers the measured number.
By their numbers in this assay, from the lowest: compounds 2, 4 and 1 (each within the scatter of the next). At a limit, above all of these: compound 3.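

In this assay, hexyl in place of phenyl on the carbonyl carbon, two groups equal in heavy atoms of which only phenyl carries a ring, gives an at least 1.4-fold lower number from compound 3 to compound 4 (0.15 log units; that floor lies within the scatter). The value of compound 3 is a limit of the assay, so this step is a floor with no measured size: the limit of > 100 mg/kg in this assay, at which 1 of the 4 values shown sits. With a 1.2-fold higher number from compound 2 to compound 4 (0.08 log units; within the scatter) and a 1.3-fold lower number from compound 1 to compound 4 (0.11 log units; within the scatter), the saturated chain on the carbonyl carbon now runs from methyl through pentyl to hexyl, and none of these steps in this assay lies beyond the scatter.

The compounds shown leave open whether phenyl on the carbonyl carbon differs at all from the saturated chains, as compound 3 offers a limit and not a number. They also leave open whether a chain longer than hexyl, or a chain carrying an amine or a carboxylic acid, would give a step beyond the scatter.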